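The source may hold more compounds than are shown below. What is called first, only, known or untested is meant among the compounds shown, and "the series" means these compounds.

Measured so far:
compound 1, `O=C(CN(c1nc(Cl)nc2[nH]cnc12)C1CC1)NCC(=O)OCc1ccccc1` — 19%
compound 2, `CC(C)[C@H](NC(=O)CN(c1nc(Cl)nc2[nH]cnc12)C1CC1)C(=O)OCc1ccccc1` — 23.6%

In a functional assay on the whole organism (Tail, strain ICR) with Mus musculus as the target, in the tail flick test, with a stated time of 90 min, at a dose of 12.5 umol/kg by the oral route (a lower number here means a weaker effect, a higher number a stronger effect of the compound at the dose given), compound 1 gives 19% and compound 2 gives 23.6%. Within the data shown here, compound 2 stands beside compound 1 as one of only two numbers so far; the single step between them, a number 4.6 percentage points higher from compound 1 to compound 2 (within the scatter), lies within the scatter, so the two cannot be told apart.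

Compound 3, `NCCCC[C@H](NC(=O)CN(c1nc(Cl)nc2[nH]cnc12)C1CC1)C(=O)OCc1ccccc1`, is the next compound. It differs from compound 2 in one place: 4-aminobutyl in place of isopropyl on a saturated chain carbon bound to an amide-type nitrogen and a carbonyl carbon.

Among the measured compounds shown here, only one measured step bears on this change, the one at the same place, a number 4.6 percentage points higher from compound 1 to compound 2 (within the scatter), which exchanged hydrogen for isopropyl and left the read-out essentially where it was. The exchange of isopropyl for 4-aminobutyl is a different kind of change, and nothing has been measured for it here. With only a step within the scatter as a guide, the expectation is a step of no more than the scatter, in either direction, with a broad range.

Compound 3 is therefore expected to give 22%, between 8% and 38%. The expected step is a number 1.6 percentage points lower from compound 2 to compound 3 (within the scatter).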

Compound 3, a percentage reported as activity, at one dose (the size of the read-out at that dose, not a potency): 25.4%
Beside the measured number, compound 3's estimate is 3.4 percentage points below it; the measured number falls inside the stated range.
By their numbers in this assay, from the lowest: compounds 1, 2 and 3 (each within the scatter of the next).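

At the place on a saturated chain carbon bound to an amide-type nitrogen and a carbonyl carbon, a side chain ending in an amine can now be set against one made of carbon alone. In this assay, the exchange of isopropyl for 4-aminobutyl gives a step that stays within the scatter (a number 1.8 percentage points higher from compound 2 to compound 3 (within the scatter)), and so does the exchange of hydrogen for 4-aminobutyl (a number 6.4 percentage points higher from compound 1 to compound 3 (within the scatter)), so hydrogen, isopropyl and 4-aminobutyl cannot be told apart at this dose, even though the groups differ in size and the last one carries a nitrogen. No measurement shown here offers an explanation for this result.

As far as these compounds go, it remains open whether a carboxylic acid on the side chain, or a benzyl group at the same place, would give a read-out that differs by more than the scatter. From the compounds shown here alone, because each compound is represented by a single read-out at one dose and one time, it also remains open whether these three compounds would still be indistinguishable at other doses or times.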